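Halogen placement on the pendant aryl: notes toward compound 3

This account rests on a few compounds, and the source may have more. Where it says the series, first, only, none or still open, it means among the compounds named here.

Measured: compound 1 `COc1cc(-n2cnc3ccc(-c4ccccc4Cl)cc32)cc(OC)c1OC` gives > 10000 nM in a functional assay on A549 cells (Homo sapiens) for antiproliferative activity, read by MTT assay, with a stated time of 72 h; a lower number here means a stronger inhibitor, a higher number a weaker inhibitor; compound 2 `COc1cc(-n2cnc3ccc(-c4ccc(F)cc4)cc32)cc(OC)c1OC` gives 6740 nM in this assay. Not yet measured: compound 3 `COc1cc(-n2cnc3ccc(-c4cccc(Cl)c4)cc32)cc(OC)c1OC`.

Compound 1 shows only a limit of this assay, not a number. Within the data shown here, compound 2 holds the only number in the set, with the other value sitting at a limit (the limit of > 10000 nM in this assay, at which 1 of the 2 values shown sits). Among the measured compounds shown here, the single measured step, an at least 1.4-fold lower number from compound 1 to compound 2 (0.17 log units; that floor lies within the scatter), has a floor within the scatter and so sets no clear direction. Compound 3 differs from compound 2 by 3-chlorophenyl in place of 4-fluorophenyl on an aromatic carbon. With one halogen-aryl swap already within scatter, no step beyond the scatter is expected for compound 3, estimated at 5500 nM (range 1500 nM to 20000 nM). The expected step is a 1.2-fold lower number from compound 2 to compound 3 (0.09 log units; within the scatter).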

Compound 3, half-maximal inhibitory concentration: 7050 nM
For compound 3 the middle estimate is 1.3-fold (0.11 log units) below the measured one; measured number inside the range.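

In this assay, among these compounds, the swap gives a 1.0-fold higher number from compound 2 to compound 3 (0.02 log units; within the scatter), the first step with a number at both ends, so 3-chlorophenyl and 4-fluorophenyl cannot be told apart at this position. With 3-chlorophenyl in place of 2-chlorophenyl, the result is an at least 1.4-fold lower number from compound 1 to compound 3 (0.15 log units; that floor lies within the scatter), which again sets no clear direction. Compound 1 gives a limit, not a number: the limit of > 10000 nM in this assay, at which 1 of the 3 values shown sits.

Still open, on these data alone, is how far compound 1 lies from compound 2 and compound 3. Also open, as far as these compounds go, is whether a non-halogen substituent on the pendant phenyl, such as an amine or a carboxylic acid, would give a step beyond the scatter.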